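A few compounds are considered here, and "the series" means these few. Any claim that something is new, unique, unknown or untested is made for them only; others in the source may bear on it.

Compound 1 `Cc1ccccc1Cn1cc(COc2ccc3c(=O)ccoc3c2)nn1` gives > 100000 nM in a functional assay on SW480 cells (Homo sapiens) for cytotoxicity, read by MTT assay, with a stated time of 48 h (on this read-out higher numbers stand for weaker inhibition and lower numbers for stronger inhibition), which is a limit of the assay rather than a number.
Compound 2 `O=c1ccoc2cc(OCc3cn(Cc4cccc([N+](=O)[O-])c4)nn3)ccc12` gives > 100000 nM in this assay, also a limit.
Compound 3 `O=c1ccoc2cc(OCc3cn(Cc4ccc([N+](=O)[O-])cc4)nn3)ccc12` gives 19300 nM in this assay.

Among the measured compounds shown here, compound 3 thus holds the only actual number of the three; the other two values sit at the limit of > 100000 nM in this assay, at which 2 of the 3 values shown sit. Compound 4 `N#Cc1cccc(Cn2cc(COc3ccc4c(=O)ccoc4c3)nn2)c1` has not yet been measured in this assay; it differs from compound 3 by 3-cyanophenyl in place of 4-nitrophenyl on a saturated chain carbon bound to an aromatic nitrogen. For the measured compounds named here, two measured steps bear on this. Going by the values given here, exchanging 3-nitrophenyl for 4-nitrophenyl gave an at least 5.1-fold lower number from compound 2 to compound 3 (0.71 log units; beyond the scatter), and an at least 5.1-fold lower number from compound 1 to compound 3 (0.71 log units; beyond the scatter) pointed the same way, so the 4-nitrophenyl arrangement is where the one readable number appears. Among the compounds with values here, compound 4 returns to a group attached as in 3-nitrophenyl, with a nitrile in place of the nitro; no measured pair shows how nitrile compares with nitro. The expected step is therefore a 3.1-fold higher number from compound 3 to compound 4 (0.49 log units; beyond the scatter). Compound 4 is estimated at 60000 nM, within 20000 nM to 150000 nM.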

Compound 4, half-maximal inhibitory concentration: > 100000 nM
Compound 4: no number, only a limit (the forecaster's own chance of this, stated with the estimate: 50%); middle value at least 1.6-fold (0.22 log units) away from the limit.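

The change to 3-cyanophenyl gives an at least 5.1-fold higher number from compound 3 to compound 4 (0.71 log units; beyond the scatter) in this assay, so this replacement on a saturated chain carbon bound to an aromatic nitrogen does not keep the readable value of compound 3. Of the groups shown here, only 4-nitrophenyl gives a number rather than a limit: the limit of > 100000 nM in this assay, at which 3 of the 4 values shown sit.

The steps among compound 1, compound 2 and compound 4 join two limits and cannot be read, so nitrile and nitro cannot be ranked from them. On these data alone, it remains open whether the number of compound 3 depends on the nitro group itself or on its place in 4-nitrophenyl, a question that a nitrile or an amine in place of that nitro would address.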